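Shifting a Nitro Group on a Large Hybrid Compound

The source may report more compounds than this note shows. Statements on the series, on what has been measured and on what is new or still open speak of the compounds shown alone.

Compound 1 `O=Cc1cn(-c2ccccc2)nc1-c1ccc([N+](=O)[O-])cc1` gives 97% in a functional assay on MCF7 cells (Homo sapiens) for antiproliferative activity, read by MTT assay, with a stated time of 24 h, tested at 0.001 ug/mL; on this read-out higher numbers stand for a weaker effect at the one concentration tested and lower numbers for a stronger effect. Within the data shown here, compound 2 `O=Cc1cn(-c2ccccc2)nc1-c1ccc(Cl)cc1` gives 98% in this assay, and the only measured step, a number 1 percentage points higher from compound 1 to compound 2 (within the scatter), made no difference that stands out. Compound 3 `COc1cc(/C=C/C(=O)C(=Cc2cn(-c3ccccc3)nc2-c2ccc([N+](=O)[O-])cc2)C(=O)/C=C/c2ccc(O)c(OC)c2)ccc1O`, a much larger molecule, gives 98% in this assay, level with compound 2 at the digits shown and within the scatter of compound 1, so the three sit together at the weak end. Compound 4 `COc1cc(/C=C/C(=O)C(=Cc2cn(-c3ccccc3)nc2-c2cccc([N+](=O)[O-])c2)C(=O)/C=C/c2ccc(O)c(OC)c2)ccc1O` follows: 3-nitrophenyl in place of 4-nitrophenyl on an aromatic carbon. Among the measured compounds shown here, no measured step concerns moving the nitro group, and the one step known, chloro in place of nitro, lay within the scatter. A step of no change at the digits printed from compound 3 to compound 4 (within the scatter) is therefore expected, none beyond the scatter. Compound 4 is estimated at 98%, in the range 90% to 103%.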

Compound 4, a percentage reported as activity, at one concentration (the size of the read-out at that concentration, not a potency): 96%
Beside the measured number, compound 4's estimate is 2 percentage points above it, and the stated range covers the measured number.
By their numbers in this assay, from the lowest: compounds 4, 1, 2 and 3 (each within the scatter of the next).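

The earlier step replaced the nitro group on the small compound 1, whereas this one keeps the nitro group and moves it within the much larger compound 3. In this assay the change from 4-nitrophenyl to 3-nitrophenyl gives a number 2 percentage points lower from compound 3 to compound 4 (within the scatter) and so stands out from nothing at this one concentration. Nothing available explains this result. Still open, as far as these compounds go, is whether an amine or a carboxylic acid in place of the nitro group on the large molecule would give a number beyond the scatter.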